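Swapping fluoro for 4-methylpiperazin-1-yl on compound 2

The source may report more compounds than this note shows. Statements on the series, on what has been measured and on what is new or still open speak of the compounds shown alone.

Compound 1, `COc1ccc(Nc2cc(NC(=O)c3ccccc3)ncn2)cc1`, gives 60 nM in an assay for inhibition of Receptor tyrosine-protein kinase erbB-3 variant L858R (Homo sapiens), read by mobility shift assay, with a stated time of 10 min; on this read-out lower numbers stand for stronger inhibition and higher numbers for weaker inhibition.
Compound 2, `COc1ccc(OC)c(Nc2cc(Nc3ccc(F)cc3)ncn2)c1`, gives 230 nM in this assay.
Compound 3, `COc1ccc(OC)c(Nc2cc(NC(=O)CCCC(=O)O)ncn2)c1`, reaches only the limit > 10000 nM in this assay.

Among the two numbers shown, compound 2 stands highest; compound 1 gives a lower number, yet the two differ in more than one place, so no single step links them. Within the data shown here, the one measured step, an at least 43-fold higher number from compound 2 to compound 3 (1.63 log units; beyond the scatter), removes the whole 4-fluorophenyl and ends at the limit of > 10000 nM in this assay, at which 1 of the 3 values shown sits. Compound 4, `COc1ccc(OC)c(Nc2cc(Nc3ccc(N4CCN(C)CC4)cc3)ncn2)c1`, instead keeps that ring and changes only its substituent: 4-methylpiperazin-1-yl in place of fluoro on an aromatic carbon. The measured step therefore bears on it only loosely, showing that the aryl group itself matters, not what a change on that group does. Among the measured compounds shown here, with no closer precedent, the expectation for compound 4 is a number near that of compound 2, with a step of a 1.5-fold lower number from compound 2 to compound 4 (0.19 log units; within the scatter) not beyond the scatter. Compound 4 is thus estimated at 150 nM, within a range from 40 nM to 600 nM.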

Compound 4, half-maximal inhibitory concentration: 167 nM
The estimate for compound 4 lay 1.1-fold (0.05 log units) below the measured number, and the stated range covers the measured number.
By their numbers in this assay, from the lowest: compound 1; then compounds 4 and 2 (each within the scatter of the next). At a limit, above all of these: compound 3.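

The replacement gives a 1.4-fold lower number from compound 2 to compound 4 (0.14 log units; within the scatter), so in this assay this aromatic carbon accepts 4-methylpiperazin-1-yl, with its non-aromatic ring and two hydrogen-bond acceptors, in place of the single fluorine atom without a change beyond the scatter. The earlier step spoke only for the aryl group as a whole, whereas this one isolates a substituent on that group and shows that, for this pair, its exchange leaves the number within the scatter. Nothing measured here accounts for this outcome.

With only these two substituents at this position, no trend can be drawn from them. Going by these compounds, it remains open whether a carboxylic acid, a primary amine or a morpholine ring on the same carbon would also stay within the scatter of compound 2.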